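This account rests on a few compounds, and the source may have more. Where it says the series, first, only, none or still open, it means among the compounds named here.

Measured compounds:
compound 1, `CN(C)CCn1cnnc1-c1cc(Oc2ccc(NC(=O)N/N=C/c3ccc(O)c(Br)c3)cc2F)ccn1`, 1860 nM in a functional assay on MKN-45 cells (Homo sapiens) for cytotoxicity, read by MTT assay, with a stated time of 72 h; on this read-out higher numbers stand for weaker inhibition and lower numbers for stronger inhibition
compound 2, `CN(C)CCn1cnnc1-c1cc(Oc2ccc(NC(=O)N/N=C/c3ccccc3O[N+](=O)[O-])cc2F)ccn1`, 1020 nM in this assay

Compound 1 stands at the highest of the two numbers in this assay; its nearest neighbour is compound 2, and the step of a 1.8-fold lower number from compound 1 to compound 2 (0.26 log units; within the scatter) lies within the scatter. Compound 3, `CN(C)CCn1cnnc1-c1cc(Oc2ccc(NC(=O)N/N=C/c3ccc(O)c(O)c3)cc2F)ccn1`, has not yet been measured in this assay. Compound 3 differs from compound 1 by hydroxy in place of bromo on an aromatic carbon, that is, a hydroxy in place of bromo on an aromatic carbon of a six-membered aromatic ring of carbon only. Within the data shown here, no measured step exchanges exactly these two groups; the only step at that part of the molecule, a 1.8-fold lower number from compound 1 to compound 2 (0.26 log units; within the scatter), replaced the whole aryl and stayed within the scatter. On that evidence the step of a 1.1-fold higher number from compound 1 to compound 3 (0.03 log units; within the scatter) is expected to stay within the scatter as well. Compound 3 is therefore estimated at 2000 nM in this assay, with a range from 700 nM to 6000 nM.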

Compound 3, half-maximal inhibitory concentration: 3240 nM
Beside the measured number, compound 3's estimate is 1.6-fold (0.21 log units) below it, within the range that was stated.
By their numbers in this assay, from the lowest: compounds 2, 1 and 3 (each within the scatter of the next, the first and the last beyond it).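

In this assay the exchange of bromo for hydroxy on an aromatic carbon, ortho to a hydroxy group, gives a 1.7-fold higher number from compound 1 to compound 3 (0.24 log units; within the scatter) and so does not separate these two compounds. Among these compounds, the exchange of the whole aryl now gives a 3.2-fold higher number from compound 2 to compound 3 (0.50 log units; beyond the scatter) as the first step beyond the scatter, a modest one, which shows that the group on the carbon with a double bond to nitrogen can alter this number, even though compound 1 lies within the scatter of both other compounds. Nothing given here bears on the cause of either step.

The compounds leave open whether methoxy, an amine or a carboxylic acid on this aromatic carbon would stay within the scatter of bromo and hydroxy. On these data alone, it also remains open whether the step between the two aryl groups follows from the nitrooxy group itself or from its place on the ring.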